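A few compounds are considered here, and "the series" means these few. Any claim that something is new, unique, unknown or untested is made for them only; others in the source may bear on it.

In a functional assay on Bel-7402 cells (Homo sapiens) for inhibition, read by sulforhodamine B assay, with a stated time of 72 h (on this read-out higher numbers stand for weaker inhibition and lower numbers for stronger inhibition), three compounds have been measured, and none of them gives an exact number. Compound 1 (`C[C@H](Nc1ncnc2[nH]cnc12)c1nn(-c2cccnc2)c2cc(Cl)ccc12`) gives > 40000 nM as a limit of the assay and not a number. Compound 2 (`C[C@H](Nc1nc(N)nc2[nH]cnc12)c1nn(-c2cccnc2)c2cc(F)ccc12`) gives > 40000 nM as a limit too. Compound 3 (`C[C@H](Nc1ncnc2[nH]cnc12)c1nn(-c2cccnc2)c2cc(F)ccc12`) gives > 40000 nM as a limit as well. Compound 3 therefore stands with the other two at the limit of > 40000 nM in this assay, at which 3 of the 3 values shown sit, and has no exact place on the scale.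

Compound 4 (`C[C@H](Nc1ncnc2[nH]cnc12)c1nn(-c2cccc(S(C)(=O)=O)c2)c2cc(F)ccc12`) keeps the core of compound 3 and alters one group. The change is 3-(methylsulfonyl)phenyl in place of pyridin-3-yl on an aromatic nitrogen and in words it is 3-(methylsulfonyl)phenyl in place of pyridin-3-yl on an aromatic nitrogen.

Two measured steps lie close to this one, namely a step that the two limits leave unreadable from compound 1 to compound 3 and a step that the two limits leave unreadable from compound 2 to compound 3 and neither has a readable size. Neither of them alters the pyridin-3-yl group either, so they offer no measure for this swap. No step beyond the usual scatter is therefore expected in this assay and neither direction is favoured. The estimated step is a number no higher from compound 3 to compound 4 (the limit leaves the size open) and it should be read with that caution. Compound 4 is estimated at 40000 nM with an expected range from 15000 nM to 80000 nM and a report of only a limit is the likeliest outcome.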

Compound 4, half-maximal inhibitory concentration: 20000 nM
Beside the measured number, compound 4's estimate is 2.0-fold (0.30 log units) above it, and the stated range covers the measured number.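

In this assay, putting 3-(methylsulfonyl)phenyl in place of pyridin-3-yl on the aromatic nitrogen gives an at least 2.0-fold lower number from compound 3 to compound 4 (0.30 log units; that floor lies within the scatter). Since compound 3 is known only as a limit, this step has a floor but no upper end, so the data cannot show whether the true difference lies beyond the scatter. The earlier steps changed other parts of the molecule and cannot be read, whereas this change to the group on the aromatic nitrogen gives compound 4 an exact number and sets it apart from the compounds that remain at the limit: the limit of > 40000 nM in this assay, at which 3 of the 4 values shown sit.

The compounds shown leave open whether the carbon-only ring or the methylsulfonyl group matters for this result, and a plain phenyl group on the same nitrogen would help to separate the two. They also leave open how other groups on that ring, such as an amine or a carboxylic acid, would read in this assay, and whether the swap would give a similar result with chloro in place of fluoro.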